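The compounds below may be only part of what the source reports. "The series", "measured", "known", "first", "only" and "open" are said of these compounds alone.

Compound 2 `COc1cc(Cl)cc(-c2nn(-c3cccc(NC(=O)Nc4ccc(Cl)c(C(F)(F)F)c4)c3)cc2-c2ccncc2)c1` stands lowest of the three numbers measured in a functional assay on OVCAR-3 cells (Homo sapiens) for inhibition, read by sulforhodamine B assay, with a stated time of 48 h, tested at 10 uM; on this read-out higher numbers stand for a weaker effect at the one concentration tested and lower numbers for a stronger effect: in this assay compound 2 gives -22.6%. Among the measured compounds shown here, compound 1 `O=C(Nc1cccc(-n2cc(-c3ccncc3)c(-c3cc(O)cc(Cl)c3)n2)c1)Nc1ccc(Cl)c(C(F)(F)F)c1` gives 1.88% in this assay, and the single-place step between them, a number 24.5 percentage points lower from compound 1 to compound 2 (beyond the scatter), is the only measured step available. Compound 3 `COc1cc(Cl)cc(-c2nn(-c3cccc(NC(=O)Nc4cc(C(F)(F)F)cc(C(F)(F)F)c4)c3)cc2-c2ccncc2)c1` gives -1.62% in this assay; its gap to compound 2 lies beyond the scatter, though the two are not linked by a recorded single-place step. Compound 4 `COc1cc(Cl)cc(-c2nn(-c3cccc(NC(=O)c4cccc(C(F)(F)F)c4)c3)cc2-c2ccncc2)c1` differs from compound 2 by 3-(trifluoromethyl)phenyl in place of (4-chloro-3-(trifluoromethyl)phenyl)amino on a carbonyl carbon. For the measured compounds named here, no measured step bears on this change: the step from compound 1 to compound 2 concerns a methyl in place of hydrogen on an oxygen on an aromatic ring, not the carbonyl carbon. The two values of compound 2 and compound 3 show that altering the group on that side of the molecule can shift the number upward. Compound 4 is therefore expected to read higher, with an estimated step of a number 27.6 percentage points higher from compound 2 to compound 4 (beyond the scatter), giving an expected value of 5%, between -20% and 30%.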

Compound 4, a percentage reported as activity, at one concentration (the size of the read-out at that concentration, not a potency): 52.3%
For compound 4 the middle estimate is 47.3 percentage points below the measured one, and the stated range ends below it.
By their numbers in this assay, from the lowest: compound 2; then compounds 3 and 1 (each within the scatter of the next); then compound 4.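

On the carbonyl carbon whose other neighbour is an amide-type nitrogen, the group is far from interchangeable: a number 74.9 percentage points higher from compound 2 to compound 4 (beyond the scatter) in this assay, so 3-(trifluoromethyl)phenyl in place of (4-chloro-3-(trifluoromethyl)phenyl)amino gives a much weaker effect at the one concentration tested. This large step shows that this position can matter more than the modest change on the oxygen, a number 24.5 percentage points lower from compound 1 to compound 2 (beyond the scatter). Nothing shown explains the step, and the data give no measured property or other support for a cause.

The change removes the amino nitrogen with its hydrogen-bond donor and also the chlorine, so the compounds shown cannot assign the step to either one. A compound carrying (3-(trifluoromethyl)phenyl)amino on the same carbonyl carbon would separate the two, leaving only the chlorine changed relative to compound 2.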